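The source may hold more compounds than are shown below. What is called first, only, known or untested is meant among the compounds shown, and "the series" means these compounds.

Compound 1, `CC(=O)N(/N=N/c1ccc(Cl)c(C(F)(F)F)c1)c1ccc(Cl)c(C(F)(F)F)c1`, gives 50600 nM in a functional assay on HeLa cells (Homo sapiens) for cytotoxicity, read by MTT assay, with a stated time of 72 h; a lower number here means a stronger inhibitor, a higher number a weaker inhibitor.
Compound 2, `CC(=O)N(/N=N/c1ccc([N+](=O)[O-])cc1)c1ccc([N+](=O)[O-])cc1`, gives 63000 nM in this assay.
Compound 3, `CC(=O)N(/N=N/c1ccc([N+](=O)[O-])cc1Br)c1ccc([N+](=O)[O-])cc1Br`, gives 550 nM in this assay.

Among these three, compound 3 stands lowest in this assay. Compound 1 lies nearest to it and compound 2 furthest, and both gaps are well beyond the scatter of repeated measurements, so compound 3 is the strongest of the three.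

Compound 4, `O=C(c1cccc(C(F)(F)F)c1)N(/N=N/c1ccc([N+](=O)[O-])cc1Br)c1ccc([N+](=O)[O-])cc1Br`, has not yet been measured. It differs from compound 3 in one place: 3-(trifluoromethyl)phenyl in place of methyl on a carbonyl carbon. Within the data shown here, none of the measured compounds are separated by a single change, and none of them vary at the carbonyl carbon at all; the measured set varies only the two aryl rings. Nothing in the numbers therefore points to a direction for this step. The expectation is a step of modest size in this assay, either upward or downward, quite possibly within the scatter.

The estimate for compound 4 in this assay is 800 nM. Its range is expected to run from 150 nM to 4000 nM. Against compound 3 this is expected to mean a step of a 1.5-fold higher number from compound 3 to compound 4 (0.16 log units; within the scatter).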

Compound 4, half-maximal inhibitory concentration: 1120 nM
Beside the measured number, compound 4's estimate is 1.4-fold (0.15 log units) below it; the range from low to high includes it.
By their numbers in this assay, from the lowest: compound 3; then compound 4; then compounds 1 and 2 (each within the scatter of the next).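

Among these compounds, the carbonyl carbon, which stayed fixed among the earlier compounds, now shows that its substituent can change the number: in this assay the exchange of methyl for 3-(trifluoromethyl)phenyl gives a 2.0-fold higher number from compound 3 to compound 4 (0.31 log units; beyond the scatter) for this one pair. The step is modest and only just clears the scatter, even though a single carbon gives way to a group of many more heavy atoms carrying a six-membered aromatic ring, so this position accepts a far larger group with only a modest rise in the number. No measurement at hand bears on why the number moves in this direction.

As far as these compounds go, whether the step comes from the aromatic ring itself or from its trifluoromethyl group stays open, as does how a plain phenyl, a longer alkyl chain, or a phenyl ring bearing an amine or a carboxylic acid would behave on this carbonyl carbon. From the compounds shown here alone, it is equally open whether the same exchange would give a step of similar size on the differently substituted aryl rings of compound 1 or compound 2, since this single pair fixes neither a trend at the position nor its reach beyond compound 3 and compound 4.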